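The source may report more compounds than this note shows. Statements on the series, on what has been measured and on what is new or still open speak of the compounds shown alone.

Measured so far in a functional assay on the whole organism (strain Wistar) for inhibition, with Rattus norvegicus as the target, with stated times of 30 min and 3 h, at a dose of 20 mg/kg by the oral route; on this read-out lower numbers stand for less inhibition and higher numbers for more inhibition at the one dose given (going by the name of the read-out):
- compound 1 `COc1ccc(/C=C2\C=C(c3ccc(Cl)cc3)OC2=O)cc1`: 32.3%
- compound 2 `COc1ccc(/C=C2\C=C(c3ccc(Cl)cc3)OC2=O)cc1OC`: 36%

The two numbers lie within the usual scatter of each other; the only measured step, a number 3.7 percentage points higher from compound 1 to compound 2 (within the scatter), is too small to count as a change, so neither compound can be set above the other on the numbers shown.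

Compound 3 `COc1cc(/C=C2\C=C(c3ccc(Cl)cc3)OC2=O)ccc1OC(C)=O` has not yet been run in this assay. It differs from compound 2 by acetyl in place of methyl on an oxygen on an aromatic ring.

Within the data shown here, no measured step bears directly on this change: the one step known, methoxy in place of hydrogen on an aromatic carbon, concerns a different group and a different place, and was itself within the scatter. Nothing in the two values speaks for a shift beyond the scatter in either direction.

The step expected is no change at the digits printed from compound 2 to compound 3 (within the scatter). Compound 3 is therefore estimated at 36%, with a range of 22% to 50%.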

Compound 3, a percentage reported as inhibition, in the whole organism at one dose (the size of the read-out at that dose, not a potency): 37%
Compound 3: the middle estimate sits 1 percentage points below what was measured; low and high end bracket the measured number.
By their numbers in this assay, from the lowest: compounds 1, 2 and 3 (each within the scatter of the next).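

In this assay, the swap of methoxy for acetoxy on this aromatic ring gives a number 1 percentage points higher from compound 2 to compound 3 (within the scatter), so on the numbers shown, compound 2 and compound 3 cannot be told apart. This position therefore accepts acetyl in place of methyl on the oxygen, with its added carbonyl and hydrogen-bond acceptor, without a difference beyond the scatter at this one dose. Nothing available explains why the two groups read alike.

As far as these compounds go, whether a free hydroxyl, a longer acyl chain such as butyryl, or an amine at this place would also stay within the scatter remains open. All three compounds keep the same chlorine-bearing aromatic ring, so the effect of a nitrile or a carboxylic acid on that ring is also unknown.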